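Methyl on the benzyl ring of the shared core

The source may hold more compounds than are shown below. What is called first, only, known or untested is meant among the compounds shown, and "the series" means these compounds.

Compound 1 `Cc1c(C(=O)c2ccccc2)cc(C(=O)NCc2cccc(I)c2)n1Cc1ccccc1`: > 100000 nM
Compound 2 `Cc1c(C(=O)c2ccccc2)cc(C(=O)NCc2cccc(Cl)c2)n1Cc1ccccc1`: > 100000 nM

Both readings come from a functional assay on Jurkat cells (Homo sapiens) for antiproliferative activity, read by MTT assay, with a stated time of 48 h; a lower number here means a stronger inhibitor, a higher number a weaker inhibitor. For compound 1 the value is a limit of the assay, not a number. For compound 2 the value is likewise only a limit. The step that the two limits leave unreadable from compound 1 to compound 2 is therefore unreadable; both compounds sit at the limit of > 100000 nM in this assay, at which 2 of the 2 values shown sit.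

Compound 3 `Cc1ccc(Cn2c(C(=O)NCc3cccc(Cl)c3)cc(C(=O)c3ccccc3)c2C)cc1` differs from compound 2 by methyl in place of hydrogen on an aromatic carbon. Among the measured compounds shown here, no measured step bears on this change; the one step known, chloro for iodo, is itself unreadable and gives neither size nor direction. With compound 2 at a limit and compound 1 at the same limit, the expectation for compound 3 is that it stays at that limit as well. The expected step that the limit leaves unreadable from compound 2 to compound 3 is thus none beyond the scatter. Compound 3 is expected at 150000 nM, with a range from 40000 nM to 500000 nM, most likely reported as a limit again.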

Compound 3, half-maximal inhibitory concentration: > 100000 nM
Compound 3 was reported as a limit; the forecaster's own chance of this, stated with the estimate: 85%; the middle value lies beyond the limit too.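

Compound 2 and compound 3 are both reported only as a limit in this assay, so no step between them can be read: the limit of > 100000 nM in this assay, at which 3 of the 3 values shown sit.

Left open is whether methyl in place of hydrogen, or chloro in place of iodo, changes the activity of the shared core at all.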